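Removing a methyl from a ring nitrogen: a small step expected

A few compounds are considered here, and "the series" means these few. Any claim that something is new, unique, unknown or untested is made for them only; others in the source may bear on it.

Measured so far:
Compound 1 `Cc1cc2[nH]nc(N)c2c(=O)[nH]1` gives 10% in an assay on isolated protein for inhibition of protein kinase C zeta type (Homo sapiens), read by mobility shift assay, tested at 30 uM; on this read-out lower numbers stand for less inhibition and higher numbers for more inhibition at the one concentration tested (going by the name of the read-out).
Compound 2 `Cc1cc2c(c(N)nn2C)c(=O)[nH]1` gives 0% in this assay.
Compound 3 `Cc1cc2c(cn1)c(N)nn2C` gives -59% in this assay.

Compound 1 and compound 2 share a core and differ in one place: hydrogen in place of methyl on an aromatic nitrogen. That step changed the read-out by a number 10 percentage points higher from compound 2 to compound 1 (within the scatter), so the two values cannot be told apart. Compound 3 stands lowest of the three, well apart from compound 2 and compound 1; the difference between its core and that of compound 2 is not broken down here.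

Compound 4 `Cc1cc2[nH]nc(N)c2cn1` has not been measured. It is compound 3 with the same change: hydrogen in place of methyl on an aromatic nitrogen. Because the earlier step was a number 10 percentage points higher from compound 2 to compound 1 (within the scatter), the step from compound 3 to compound 4 is expected to be small too, about a number 14 percentage points higher from compound 3 to compound 4 (beyond the scatter). Compound 4 is therefore estimated at -45%, within -80% to -5%.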

Compound 4, a percentage reported as inhibition, at one concentration (the size of the read-out at that concentration, not a potency): -275%
Estimate against measurement, compound 4: 230 percentage points above; the measured number lies below the stated range.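

In this assay, putting hydrogen in place of the methyl on the aromatic nitrogen gives a number 216 percentage points lower from compound 3 to compound 4 (beyond the scatter), so this change cannot be carried from one core to another in this series as a fixed step. The two cores respond differently to the same change: the same change on two cores in this assay, a number 10 percentage points higher (within the scatter) from compound 2 to compound 1 and a number 216 percentage points lower (beyond the scatter) from compound 3 to compound 4, 226 percentage points apart, beyond the scatter of two such steps. This shows that the size of the step depends on the core that carries it, but two pairs of compounds do not show which part of the core matters or what a third core would do.

The compounds shown leave open how an ethyl group or a longer chain on that same nitrogen would read in this assay. They also leave open whether either would follow the same split between the two cores.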